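The compounds below may be only part of what the source reports. "The series", "measured", "known", "first", "only" and "open" are said of these compounds alone.

Measured so far in a functional assay on SNU-475 cells (Homo sapiens) for inhibition, read by sulforhodamine B assay, with a stated time of 72 h; on this read-out higher numbers stand for weaker inhibition and lower numbers for stronger inhibition:

Compound 1, `Cc1ccc(C2=Nn3c(nnc3C(C)c3ccc(CC(C)C)cc3)SC2)cc1`, gives 8700 nM.
Compound 2, `CC(C)Cc1ccc(C(C)c2n[nH]c(=S)n2N)cc1`, gives 11700 nM.
Compound 3, `CC(c1ccc(-c2ccccc2)c(F)c1)c1nnc2n1N=C(c1ccc(Cl)cc1Cl)CS2`, gives 4700 nM.

Compound 3 has the lowest of the three numbers. Its gap to compound 1 lies within the usual scatter, so no order between those two can be read; its gap to compound 2 lies beyond the scatter, so compound 3 stands clearly lower than compound 2 in this assay.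

Compound 4, `COc1ccc(C2=Nn3c(nnc3C(C)c3ccc(-c4ccccc4)c(F)c3)SC2)cc1`, has not yet been measured. It differs from compound 3 in one place: 4-methoxyphenyl in place of 2,4-dichlorophenyl on a carbon with a double bond to nitrogen. Going by the values given here, no pair of measured compounds shows this change on its own, so the expectation rests on the value of compound 3 alone and carries wide uncertainty. The expected step, a 1.5-fold higher number from compound 3 to compound 4 (0.17 log units; within the scatter), is a small move toward a higher number, not clearly beyond the usual scatter. In this assay compound 4 is expected to give 7000 nM, with a range from 2500 nM to 20000 nM.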

Compound 4, half-maximal inhibitory concentration: 6700 nM
Compound 4: the middle estimate sits 1.0-fold (0.02 log units) above what was measured; measured number inside the range.
By their numbers in this assay, from the lowest: compounds 3, 4, 1 and 2 (each within the scatter of the next, the first and the last beyond it).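

Exchanging the group on the carbon with a double bond to nitrogen, 4-methoxyphenyl in place of 2,4-dichlorophenyl, gives a 1.4-fold higher number from compound 3 to compound 4 (0.15 log units; within the scatter) in this assay, so no order can be read between these two compounds. Going by these compounds alone, this is the first comparison here in which only one place differs, and it shows that at this position the two chlorine atoms can give way to a methoxy group, with its one hydrogen-bond acceptor, without a change that stands clear of the scatter. Nothing available bears on why the two groups read alike. As far as these compounds go, it remains open how this position would respond to a group of another kind, such as an amine or a carboxylic acid. From the compounds shown here alone, it is also open whether the same exchange would read alike with the other substituent of compound 1 on the shared core.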